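Butyl in place of chloro on the shared aryl ketoacid core

The compounds below may be only part of what the source reports. "The series", "measured", "known", "first", "only" and "open" are said of these compounds alone.

Measured so far in a functional assay on LS174T cells (Homo sapiens) for inhibition, read by MTT assay, with a stated time of 72 h; on this read-out higher numbers stand for weaker inhibition and lower numbers for stronger inhibition:
compound 1 `O=C(O)/C=C/C(=O)c1ccc(Cl)cc1Cl`, > 100000 nM
compound 2 `O=C(O)/C=C/C(=O)c1ccc(Cl)cc1`, 28700 nM
compound 3 `O=C(O)/C=C/C(=O)c1ccc(Cl)c(Cl)c1`, 32300 nM.

For compound 1 the value given is a limit of the assay, not a number (the limit of > 100000 nM in this assay, at which 1 of the 3 values shown sits). Compound 2 gives the lowest of the two numbers shown, with compound 3 within the scatter of it. The steps measured so far are an at least 3.4-fold lower number from compound 1 to compound 2 (0.54 log units; beyond the scatter) and a 1.1-fold higher number from compound 2 to compound 3 (0.05 log units; within the scatter); both concern removal or addition of a chloro group, not a butyl chain.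

Compound 4 `CCCCc1ccc(C(=O)/C=C/C(=O)O)cc1` differs from compound 2 as follows: butyl in place of chloro on an aromatic carbon. Among the compounds with values here, no measured step covers this exchange, so the expectation for this assay is a step of no more than the scatter, in either direction, from compound 2: a 1.1-fold lower number from compound 2 to compound 4 (0.06 log units; within the scatter). Compound 4 is therefore estimated at 25000 nM, in the range 8000 nM to 80000 nM.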

Compound 4, half-maximal inhibitory concentration: 6740 nM
Beside the measured number, compound 4's estimate is 3.7-fold (0.57 log units) above it; measured number outside the range, below it.
By their numbers in this assay, from the lowest: compound 4; then compounds 2 and 3 (each within the scatter of the next). At a limit, above all of these: compound 1.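

In this assay the exchange of chloro for butyl, on the aromatic carbon para to a group of 7 heavy atoms, gives a 4.3-fold lower number from compound 2 to compound 4 (0.63 log units; beyond the scatter) and shows that this carbon can carry a chain without loss of inhibition. Within the data shown here, the earlier steps only removed or added a chloro group, so this is the first exchange of the group on this carbon itself. Nothing shown here explains the step.

From the compounds shown here alone, whether the number follows chain length stays open, since this single step fixes no trend and a propyl or a hexyl chain would test it. Also open, going by these compounds, is whether an amine or a methoxy group on the same carbon would move the number in the same direction.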